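Working notes: from compound 2 to compound 4

The compounds below may be only part of what the source reports. "The series", "measured", "known", "first", "only" and "open" are said of these compounds alone.

Measured in a functional assay on A549 cells (Homo sapiens) for antiproliferative activity, read by MTT assay, with a stated time of 24 h; on this read-out higher numbers stand for weaker inhibition and lower numbers for stronger inhibition
compound 1 `Cc1cccc(NNC(=O)c2ccc(NS(=O)(=O)c3cnc(O)nc3O)cc2)c1` gives > 20000 nM
compound 2 `O=C(NNc1ccccc1F)c1cccc(NS(=O)(=O)c2cnc(O)nc2O)c1` gives 11100 nM
compound 3 `O=C(NNC(=O)c1cccc(Cl)c1)c1ccc(NS(=O)(=O)c2cnc(O)nc2O)cc1` gives 2290 nM

Compound 1 shows only a limit of the assay, > 20000 nM, and not a number. Compound 2 has the higher of the two actual numbers in this assay at 11100 nM against compound 3 at 2290 nM.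

Compound 4 `O=C(NNC(=O)c1cccc(NS(=O)(=O)c2cnc(O)nc2O)c1)c1ccc(F)cc1` is still unmeasured. The difference from compound 2 is (4-fluorophenyl)carbonyl in place of 2-fluorophenyl on an amine nitrogen, so a carbonyl-bearing group replaces a directly attached aryl group on an amine nitrogen.

Among the compounds with values here, one measured step bears on this, a change of the same kind: an at least 8.7-fold lower number from compound 1 to compound 3 (0.94 log units; beyond the scatter). This is a single step, its size rests on a limit, and the ring substituents differ, so only part of that size is carried over. The expected change is a 3.7-fold lower number from compound 2 to compound 4 (0.57 log units; beyond the scatter), towards stronger inhibition in this assay and beyond the scatter. For compound 4 the estimated value is 3000 nM with an expected range from 1000 nM to 9000 nM in this assay.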

Compound 4, half-maximal inhibitory concentration: > 20000 nM
Compound 4: no number, only a limit (the forecaster's own chance of this, stated with the estimate: 3%); middle value at least 6.6-fold (0.82 log units) from the limit.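

In this assay compound 4 gives > 20000 nM, which is a limit of the assay and not a number. The change on this amine nitrogen therefore does not carry a single direction across the two pairs: the earlier step was an at least 8.7-fold lower number from compound 1 to compound 3 (0.94 log units; beyond the scatter), whereas the new one is an at least 1.8-fold higher number from compound 2 to compound 4 (0.25 log units; that floor lies within the scatter), so a carbonyl-bearing group here does not by itself bring a lower number, though the floor of the new step does not establish a rise beyond the scatter. The true size of the new step cannot be read, and the limit now recurs in this small set: the limit of > 20000 nM in this assay, at which 2 of the 4 values shown sit.

As far as these compounds go, it remains open whether the opposite outcomes of the two steps go with the ring substituent on the carbonyl group or with the way the core differs between the two pairs. From the compounds shown here alone, how an amine or a longer chain would read on this nitrogen also remains open.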